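Notes on the chain at the double-bonded nitrogen

A few compounds are considered here, and "the series" means these few. Any claim that something is new, unique, unknown or untested is made for them only; others in the source may bear on it.

compound 1 `CC/N=c1/c(C#N)c2n(c(=O)n1-c1ccccc1)CCC2` — 24.5%
compound 2 `N#Cc1c2n(c(=O)n(-c3ccccc3)/c1=N\CCO)CCC2` — 25.9%

In a functional assay on the whole organism (strain albino) for inhibition, with Rattus norvegicus as the target, read by paw edema, with a stated time of 3 h, at a dose of 0.029 mmol/kg by the oral route (a lower number here means less inhibition, a higher number more inhibition at the dose given (going by the name of the read-out)), compound 2 gives 25.9% and compound 1 gives 24.5%; on these two numbers compound 2 is not set apart. For the measured compounds named here, the single measured step reads a number 1.4 percentage points higher from compound 1 to compound 2 (within the scatter).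

Compound 3 `C=CC/N=c1/c(C#N)c2n(c(=O)n1-c1ccccc1)CCC2` differs from compound 2 by vinyl in place of hydroxymethyl on a saturated chain carbon bound to a double-bonded nitrogen. Going by the values given here, the hydroxy that leaves is the very group the measured step added without a shift beyond the scatter, so that step bears on the change; the vinyl that enters has no counterpart among the measured compounds. The expected step is therefore a number 0.9 percentage points lower from compound 2 to compound 3 (within the scatter), none beyond the scatter. Compound 3 is estimated at 25%, within 12% to 38%.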

Compound 3, a percentage reported as inhibition, in the whole organism at one dose (the size of the read-out at that dose, not a potency): 23.1%
Beside the measured number, compound 3's estimate is 1.9 percentage points above it; the measured number falls inside the stated range.
By their numbers in this assay, from the lowest: compounds 3, 1 and 2 (each within the scatter of the next).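

In this assay, allyl in place of 2-hydroxyethyl gives a number 2.8 percentage points lower from compound 2 to compound 3 (within the scatter), and vinyl in place of methyl on a saturated chain carbon bound to a double-bonded nitrogen gives a number 1.4 percentage points lower from compound 1 to compound 3 (within the scatter). A double bond outside aromatic rings thus joins the hydroxy as a change that does not separate these compounds at this dose. Nothing at hand bears on why the numbers lie so close.

On these data alone, whether a terminal amine, a carboxylic acid or a longer chain at this position would give a step beyond the scatter remains open. As far as these compounds go, whether these three compounds would also stay together at another dose remains open as well.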